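This account rests on a few compounds, and the source may have more. Where it says the series, first, only, none or still open, it means among the compounds named here.

Measured compounds:
- compound 1 `Oc1c(Br)ccc(Br)c1Oc1ccc(Br)cc1Br` gives 6890 nM in a functional assay on MCF7 cells (Homo sapiens) for antiproliferative activity; on this read-out lower numbers stand for stronger inhibition and higher numbers for weaker inhibition
- compound 2 `Oc1c(Br)c(Br)cc(Br)c1Oc1ccc(Br)cc1Br` gives 7520 nM in this assay

Compound 2 gives the highest of these two numbers, yet its value sits close to that of compound 1, a gap within the scatter. The next compound, compound 3 `Oc1c(Oc2ccc(Br)cc2Br)ccc(Br)c1Br`, is not yet measured. Its change from compound 2 is hydrogen in place of bromo on an aromatic carbon. Within the data shown here, the one measured step that bears on it, a 1.1-fold higher number from compound 1 to compound 2 (0.04 log units; within the scatter), went the opposite way and barely moved the number. The step from compound 2 to compound 3 is therefore expected to be small, a 1.1-fold lower number from compound 2 to compound 3 (0.03 log units; within the scatter), with no direction beyond the scatter. Compound 3 is expected to give 7000 nM, within 3500 nM to 14000 nM.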

Compound 3, half-maximal inhibitory concentration: 7230 nM
The estimate for compound 3 lay 1.0-fold (0.01 log units) below the measured number; the measured number falls inside the stated range.
By their numbers in this assay, from the lowest: compounds 1, 3 and 2 (each within the scatter of the next).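

Taking away the bromo ortho to the group of 9 heavy atoms leaves the number within the scatter, a 1.0-fold lower number from compound 2 to compound 3 (0.02 log units; within the scatter). Among these compounds, this is a different bromo from the one that separates compound 1 from compound 2, so on this ring two separate bromo positions have now been changed, with neither step going beyond the scatter. Nothing measured here explains this.

Only hydrogen and bromo have been seen at this position. From the compounds shown here alone, whether a larger or different group there, such as an amine or a carboxylic acid, would shift the number remains open.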